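A few compounds are considered here, and "the series" means these few. Any claim that something is new, unique, unknown or untested is made for them only; others in the source may bear on it.

The account starts from compound 1 `O=C(Nc1ccc(Cl)cc1)NS(=O)(=O)c1ccc(Cl)s1`, which in a functional assay on the whole organism (6C3HED cells, Mus musculus) for inhibition, at a dose of 300 mg/kg by the oral route (a higher number here means more inhibition at the dose given (going by the name of the read-out), a lower number less inhibition), gives 89%, the highest of the three measured numbers. Compound 2 `CCCOc1ccc(S(=O)(=O)NC(=O)Nc2ccc(Cl)cc2)s1` gives 63% in this assay, and compound 3 `CC(C)(C)c1ccc(S(=O)(=O)NC(=O)Nc2ccc(Cl)cc2)s1` gives 10% in this assay, so compound 2 stands nearest to compound 1 and compound 3 furthest from it. Compound 4 `COc1csc(S(=O)(=O)NC(=O)Nc2ccc(Cl)cc2)c1` has not yet been measured in this assay; it differs from compound 1 in one place: 4-methoxythiophen-2-yl in place of 5-chlorothiophen-2-yl on a sulfonyl sulfur. Going by the values given here, two measured steps bear on this change, since both also exchange the chloro of compound 1: a number 26 percentage points lower from compound 1 to compound 2 (beyond the scatter) and a number 79 percentage points lower from compound 1 to compound 3 (beyond the scatter). The entering methoxy is an alkoxy group, as is the propoxy of compound 2, so the step from compound 1 to compound 2 is taken as the closer guide, although here the whole 5-chlorothiophen-2-yl is exchanged for 4-methoxythiophen-2-yl, which makes the comparison less direct and widens the range. Compound 4 is therefore expected to show a number 31 percentage points lower from compound 1 to compound 4 (beyond the scatter), a modest loss. Compound 4 is estimated at 58%, with a range from 25% to 85%.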

Compound 4, a percentage reported as inhibition, in the whole organism at one dose (the size of the read-out at that dose, not a potency): 69%
Beside the measured number, compound 4's estimate is 11 percentage points below it, within the range that was stated.
By their numbers in this assay, from the lowest: compound 3; then compounds 2 and 4 (each within the scatter of the next); then compound 1.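

In this assay, replacing the whole 5-chlorothiophen-2-yl on the sulfonyl sulfur with 4-methoxythiophen-2-yl gives a number 20 percentage points lower from compound 1 to compound 4 (beyond the scatter), so the chloro group is not needed for a clear inhibition read-out at this dose. The earlier steps shown here exchanged only the chloro group, whereas this one changes the entire group on the sulfonyl sulfur, and the loss is still modest rather than large. Nothing given here accounts for the size of this step.

It remains open whether the result follows from the methoxy group itself or from where it sits, as the compounds shown change both at once. Also open, going by these compounds, is how an amine, a carboxylic acid or a bromo group in place of the chloro would read in this assay.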